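The source may hold more compounds than are shown below. What is called first, only, known or untested is meant among the compounds shown, and "the series" means these compounds.

In a functional assay on HeLa cells (Homo sapiens) for antiproliferative activity, read by MTT assay, with a stated time of 72 h (on this read-out lower numbers stand for stronger inhibition and higher numbers for weaker inhibition), compound 2 `COc1cc(-c2nc(N(C)C)sc2-c2ccc(C(F)(F)F)cc2)cc(OC)c1OC` gives > 10000 nM, which is a limit of the assay and not a number. Compound 1 `CCOc1ccc(-c2sc(NC)nc2-c2cc(OC)c(OC)c(OC)c2)cc1`, which also carries an ethoxy group, gives 13.2 nM. Compound 3 `CCOc1ccc(-c2sc(N(C)C)nc2-c2cc(OC)c(OC)c(OC)c2)cc1` has ethoxy in place of the trifluoromethyl of compound 2, on an aromatic carbon: ethoxy in place of trifluoromethyl on an aromatic carbon. Going by the values given here, with compound 1 at 13.2 nM as the only guide, a large move toward stronger inhibition is expected in this assay. The expected size of this move is an at least 33-fold lower number from compound 2 to compound 3 (1.52 log units; beyond the scatter). The estimate for compound 3 is 300 nM, with an expected range of 30 nM to 4000 nM.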

Compound 3, half-maximal inhibitory concentration: 3260 nM
Compound 3: the middle estimate sits 11-fold (1.04 log units) below what was measured; the range from low to high includes it.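

In this assay, going by these compounds, ethoxy in place of trifluoromethyl on this aromatic carbon gives an at least 3.0-fold lower number from compound 2 to compound 3 (0.48 log units; beyond the scatter), a real gain whose full size stays unknown. That step starts from a limit of the assay and not a number: the limit of > 10000 nM in this assay, at which 1 of the 3 values shown sits.

With ethoxy held fixed, the nitrogen proves far more sensitive, since methyl in place of its hydrogen gives a 250-fold higher number from compound 1 to compound 3 (2.39 log units; beyond the scatter).

Still open, on these data alone, is whether a primary amine at that nitrogen, or a longer chain such as propoxy in place of ethoxy, would keep this inhibition. Also open, as far as these compounds go, is how trifluoromethyl behaves when the nitrogen carries a hydrogen, as in compound 1.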